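Bromo in place of cyano: half-life working notes

The source may hold more compounds than are shown below. What is called first, only, known or untested is meant among the compounds shown, and "the series" means these compounds.

Compound 1 `N#Cc1ccccc1Cn1c(N2CCC[C@@H](N)C2)ncc(-c2cc[nH]c2)c1=O` gives 1.18 h in an in vitro ADME assay on microsomes from liver (Rattus norvegicus) for metabolic stability, read by LC-MS; a higher number here means that the compound lasts longer, a lower number that the compound disappears faster. Compound 2 `N#Cc1ccccc1Cn1c(N2CCC[C@@H](N)C2)cc(=O)[nH]c1=O` gives > 3.33 h in this assay, and this is a limit of the assay, not a number. That places compound 2 at the limit of > 3.33 h in this assay, at which 1 of the 2 values shown sits. Its true half-life is therefore unknown, and any step away from it can only be sized roughly.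

Compound 3 `N[C@@H]1CCCN(c2cc(=O)[nH]c(=O)n2Cc2ccccc2Br)C1` differs from compound 2 by one change (bromo in place of cyano on an aromatic carbon). Bromo replaces cyano on an aromatic carbon of a six-membered aromatic ring of carbon only, ortho to a large group, so 2-cyanophenyl becomes 2-bromophenyl. Among the compounds with values here, no measured pair isolates this change, so the size of the step has no direct precedent. A modest shortening of the half-life in this assay is expected, and a result still at the limit would not be surprising. The expected change, reckoned against the limit, is an at least 1.5-fold lower number from compound 2 to compound 3 (0.18 log units; that floor lies within the scatter). For compound 3 the estimated half-life is 2.2 h, with an expected range of 0.9 h to 5 h.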

Compound 3, half-life: > 1.96 h
Compound 3: a limit, no number; the forecaster's own chance of this, stated with the estimate: 25%; the middle value does not contradict the limit.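

In this assay compound 3 gives > 1.96 h, a limit and not a number. Compound 2 also gives a limit, > 3.33 h. Within the data shown here, with both values limits, no step from compound 2 to compound 3 can be read. The compounds shown leave open how far, and in which direction, bromo in place of cyano moves the half-life.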